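This account rests on a few compounds, and the source may have more. Where it says the series, first, only, none or still open, it means among the compounds named here.

Compound 1 `Clc1ccc(COc2ccccc2/C=C/C(/C=C/c2ccccn2)=N/Oc2ncnc3cc(Cl)ccc23)c(Cl)c1` was tested in a functional assay on SMMC-7721 cells (Homo sapiens) for inhibition, read by MTT assay, with a stated time of 72 h, tested at 10 uM (a lower number here means a weaker effect, a higher number a stronger effect of the compound at the concentration tested), where compound 1 gives 91.8%. On the numbers shown, compound 1 stands lowest of three, but neither gap separates it from its neighbours: compound 3 `Fc1ccccc1COc1ccccc1/C=C/C(/C=C/c1ccccn1)=N/Oc1ncnc2cc(Cl)ccc12` gives 94.8% in this assay, and compound 2 `Clc1ccccc1COc1ccccc1/C=C/C(/C=C/c1ccccn1)=N/Oc1ncnc2ccccc12` gives 96%, both within the scatter of compound 1.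

Going by the values given here, only one measured pair differs in a single place, and it concerns the other end of the molecule: a number 3 percentage points higher from compound 1 to compound 3 (within the scatter). That step was within the scatter.

Compound 4 `Cc1cccc2ncnc(O/N=C(\C=C\c3ccccn3)/C=C/c3ccccc3OCc3ccc(Cl)cc3Cl)c12` differs from compound 1 at the oxygen whose other neighbour is a double-bonded nitrogen: 5-methylquinazolin-4-yl in place of 7-chloroquinazolin-4-yl on an oxygen. Among the compounds with values here, no measured step touches this part of the molecule. Compound 2 carries a quinazolin-4-yl group without substituent, but it also differs from compound 1 in the benzyl portion, so its values with compound 1 show only that the two lie within the scatter of each other. Within the data shown here, with the one available step, from compound 1 to compound 3, being flat, no change beyond the scatter is expected for compound 4.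

Compound 4 is therefore expected to give about 92% in this assay, between 76% and 99%. This estimate means an expected step of a number 0.2 percentage points higher from compound 1 to compound 4 (within the scatter).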

Compound 4, a percentage reported as inhibition, at one concentration (the size of the read-out at that concentration, not a potency): 93.9%
Compound 4: middle estimate off by 1.9 percentage points, on the low side, and the stated range covers the measured number.
By their numbers in this assay, from the lowest: compounds 1, 4, 3 and 2 (each within the scatter of the next).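

The first step measured at this oxygen is a number 2.1 percentage points higher from compound 1 to compound 4 (within the scatter), which shows that, in this assay, 5-methylquinazolin-4-yl can take the place of 7-chloroquinazolin-4-yl without a change that can be told from the scatter. Together with the earlier step in the benzyl portion, a number 3 percentage points higher from compound 1 to compound 3 (within the scatter), this means that single changes at both ends of the molecule have now been read, and neither gives a separable change at the concentration tested. No measurement is available that would explain this flat result, and the read-out at one concentration is not a potency, so the step gives no ranking of the two groups by potency.

The step exchanges the chlorine for a methyl and changes its place on the quinazoline at the same time, so the compounds shown cannot separate the effect of the group from that of its position. As far as these compounds go, it also remains open whether a larger change at this oxygen, such as an amine or a carboxylic acid on the quinazolin-4-yl group, would stay within the scatter.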